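Shifting a methoxy group on an oxazole-linked aryl ring

The compounds below may be only part of what the source reports. "The series", "measured", "known", "first", "only" and "open" are said of these compounds alone.

Measured so far:
compound 1 `COC(=O)c1cccc(OCc2oc(-c3cccc(OC)c3)nc2C)c1`: 17100 nM
compound 2 `COc1ccccc1-c1nc(C)c(COc2cccc(C(=O)O)c2)o1`: > 100000 nM

Two compounds share a five-membered aromatic core and an acid or ester tail, and have been tested in an assay on cells for antagonist activity at vitamin D3 receptor (Homo sapiens), read by a luciferase reporter; a higher number here means a weaker inhibitor, a lower number a stronger inhibitor. Compound 1 `COC(=O)c1cccc(OCc2oc(-c3cccc(OC)c3)nc2C)c1` gives 17100 nM. Compound 2 `COc1ccccc1-c1nc(C)c(COc2cccc(C(=O)O)c2)o1` gives only a limit, > 100000 nM, so no number is known for it; it sits at the limit described in the limit of > 100000 nM in this assay, at which 1 of the 2 values shown sits. Compound 2 therefore stands at the weak end of what the numbers show, and the two values together show that compound 1 registered an inhibitory concentration while compound 2 did not.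

Compound 3 `COc1cccc(-c2nc(C)c(COc3cccc(C(=O)O)c3)o2)c1` is compound 2 with 3-methoxyphenyl in place of 2-methoxyphenyl on an aromatic carbon, in words, 3-methoxyphenyl in place of 2-methoxyphenyl on an aromatic carbon. Among the measured compounds shown here, no measured pair shows this exact change, so its size is not known; since compound 2 sits at a limit, any step to compound 3 can only be toward stronger inhibition or none at all in this assay. Compound 3 is expected to reach a measurable value near 50000 nM, within 15000 nM to 150000 nM, which would mean an expected step of an at least 2.0-fold lower number from compound 2 to compound 3 (0.30 log units; that floor lies within the scatter).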

Compound 3, half-maximal inhibitory concentration in the vitamin D3 receptor assay: 33100 nM
Compound 3: middle estimate off by 1.5-fold (0.18 log units), on the high side, within the range that was stated.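

In the vitamin D3 receptor assay, moving the methoxy group, with 3-methoxyphenyl in place of 2-methoxyphenyl, gives an at least 3.0-fold lower number from compound 2 to compound 3 (0.48 log units; beyond the scatter), so where this group sits on the ring changes the reading even though the atoms stay the same. In the vitamin D3 receptor assay compound 2 gives > 100000 nM, which is a limit and not a number, so the true size of that step stays unknown: the limit of > 100000 nM in the vitamin D3 receptor assay, at which 1 of the 3 values shown sits.

In a physicochemical assay for solubility, tested at 500 uM (on this read-out higher numbers stand for higher solubility and lower numbers for lower solubility), compound 2 gives 423000 nM and compound 3 gives 498000 nM, two values within the scatter of each other.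

With the 3-methoxyphenyl group held in place, hydrogen in place of methyl on an oxygen next to a carbonyl group gives, in the vitamin D3 receptor assay, a 1.9-fold higher number from compound 1 to compound 3 (0.29 log units; within the scatter), so the methyl ester and the carboxylic acid cannot be told apart in this pair.

Still open, from the compounds shown here alone, is whether an ethoxy group in place of the methoxy group would keep the reading of the vitamin D3 receptor assay, and whether an amide in place of the carboxylic acid would read like the ester and the acid. Also open, going by these compounds, is how other groups on the ring attached to the shared core would behave, such as a chlorine atom or a nitrile.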